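A Thiophene for Chlorophenyl on the Cyclopropane Amide

A few compounds are considered here, and "the series" means these few. Any claim that something is new, unique, unknown or untested is made for them only; others in the source may bear on it.

Compound 1, `O=C([C@@H]1C[C@H]1c1ccccc1)N(CCNCC1CCCCC1)c1ccc(-c2ccccc2)cc1`: 6.6 nM in a functional assay for agonist activity at G protein-coupled receptor 88 (Homo sapiens), read by HTRF and cAMP accumulation; on this read-out lower numbers stand for an effect already at smaller amounts and higher numbers for an effect only at larger amounts of compound.
Compound 2, `O=C([C@@H]1C[C@H]1c1ccccc1)N(CCNCC1CCCC1)c1ccc(-c2ccccc2)cc1`: 2.5 nM.
Compound 3, `CC[C@H](C)[C@H](N)CN(C(=O)[C@@H]1C[C@H]1c1ccccc1Cl)c1ccc(-c2ccccc2)cc1`: > 25000 nM, which is a limit of the assay and not a number.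

Compound 3 stands at the limit of > 25000 nM in this assay, at which 1 of the 3 values shown sits, so only a limit is known for it. Compound 4, `CC[C@H](C)[C@H](N)CN(C(=O)[C@@H]1C[C@H]1c1ccsc1)c1ccc(-c2ccccc2)cc1`, differs from it by thiophen-3-yl in place of 2-chlorophenyl on a saturated ring carbon. Within the data shown here, the single measured step, a 2.6-fold lower number from compound 1 to compound 2 (0.42 log units; beyond the scatter), lies on the amine side chain and leaves the cyclopropane and its aryl untouched, so no measured step bears on this change. Among the measured compounds shown here, the only anchor is compound 3, which gives no number. Compound 4 is therefore expected to stay near that limit, a step estimated as an at least 1.2-fold lower number from compound 3 to compound 4 (0.09 log units; that floor lies within the scatter) with wide uncertainty. Compound 4 is estimated at 20000 nM in this assay, within 2000 nM to 25000 nM.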

Compound 4, half-maximal effective concentration: 450 nM
The estimate for compound 4 lay 44-fold (1.65 log units) above the measured number, outside the stated range (below it).
By their numbers in this assay, from the lowest: compound 2; then compound 1; then compound 4. At a limit, above all of these: compound 3.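

In this assay, among these compounds, this is the first measured change on the saturated ring carbon of the three-membered ring, and it is large, unlike the step on the amine side chain: thiophen-3-yl in place of 2-chlorophenyl gives an at least 55-fold lower number from compound 3 to compound 4 (1.74 log units; beyond the scatter). For compound 3 only a limit is known, not a number: the limit of > 25000 nM in this assay, at which 1 of the 4 values shown sits.

From the compounds shown here alone, it remains open whether the gain comes from the thiophene itself or from losing the chlorine, a question that phenyl on this side chain could address. Also open, going by these compounds, is how thiophen-2-yl or furan-3-yl would fare at this position.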